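The source may report more compounds than this note shows. Statements on the series, on what has been measured and on what is new or still open speak of the compounds shown alone.

The measured compounds:

compound 1, `COc1cc(-c2cc(/C=C/C(=O)c3ccc(N)cc3)[nH]n2)cc(OC)c1OC` — 110%
compound 2, `COc1ccc(-c2cc(/C=C/C(=O)c3ccc(OC)c(OC)c3)[nH]n2)cc1` — 107%

In a functional assay on NCI/ADR-RES cells (Homo sapiens) for cytotoxicity, read by sulforhodamine B assay, with a stated time of 48 h, tested at 0.1 uM (on this read-out lower numbers stand for a stronger effect and higher numbers for a weaker effect at the one concentration tested), compound 1 gives 110%, a read-out that speaks of no cytotoxic effect at the single concentration tested. Compound 2 gives 107% in this assay, and the two numbers lie within the usual scatter of each other, so nothing separates them. Within the data shown here, no pair of measured compounds differing in a single place is available, and so no measured step is known.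

Compound 3, `COc1cc(-c2cc(/C=C/C(=O)c3ccc(Cl)c(Cl)c3)[nH]n2)cc(OC)c1OC`, shares the core of compound 1 and differs from it by 3,4-dichlorophenyl in place of 4-aminophenyl on a carbonyl carbon. Since the two measured compounds both sit at a level of no effect, compound 3 is expected to do the same, with a step from compound 1 to compound 3 of no size beyond the scatter, a number 5 percentage points lower from compound 1 to compound 3 (within the scatter). Compound 3 is estimated at 105% in this assay, within a range of 90% to 120%.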

Compound 3, a percentage reported as activity, at one concentration (the size of the read-out at that concentration, not a potency): 96%
For compound 3 the middle estimate is 9 percentage points above the measured one; the measured number falls inside the stated range.
By their numbers in this assay, from the lowest: compound 3; then compounds 2 and 1 (each within the scatter of the next).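

In this assay, among these compounds, the group on a carbonyl carbon proves able to move the read-out: with the core of compound 1 held fixed, 3,4-dichlorophenyl in place of 4-aminophenyl gives a number 14 percentage points lower from compound 1 to compound 3 (beyond the scatter), the first measured step in this set and a modest one. Even so, compound 3 gives 96%, a number that remains close to the level of no effect at the one concentration tested. Nothing measured here gives a reason for this step.

This single step cannot tell whether the departure of the 4-aminophenyl group or the arrival of the 3,4-dichlorophenyl group accounts for the difference. It also leaves open how a 4-chlorophenyl or a 4-hydroxyphenyl group would read at this place on the same core.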